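The source may hold more compounds than are shown below. What is called first, only, known or untested is meant among the compounds shown, and "the series" means these compounds.

In an ADME assay on HCT-116 cells (Homo sapiens) for cytotoxicity, read by CellTiter-Glo, with a stated time of 72 h (a higher number here means a weaker inhibitor, a lower number a stronger inhibitor), compound 1 (`CC1CCN(C2CCN(S(=O)(=O)c3ccccc3Br)CC2)CC1`) gives > 5000 nM as a limit. Compound 2 (`CC1CCN(C2CCN(S(=O)(=O)c3cccc(-c4ccc5ccccc5c4)c3)CC2)CC1`) likewise stands only at a limit, with > 5000 nM as its reading. Compound 3 (`CC1CCN(C2CCN(S(=O)(=O)c3cccc(Cl)c3)CC2)CC1`) differs from compound 2 in one place, with chloro in place of naphthalen-2-yl on an aromatic carbon. Since compound 1 and compound 2 share the limit of > 5000 nM in this assay, at which 2 of the 2 values shown sit, as their only result, no step beyond the scatter is expected in this assay in either direction. The estimated step is a step that the limit leaves unreadable from compound 2 to compound 3 and no larger. Compound 3 is expected at about 8000 nM with a range from 5000 nM to 15000 nM and may well read as a limit again.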

Compound 3, half-maximal inhibitory concentration: > 5000 nM
Compound 3 was reported as a limit (the forecaster's own chance of this, stated with the estimate: 90%); the middle value is on the limit's open side.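

No step can be read from compound 3 to compound 2 or compound 1, as all three stand only at a limit in this assay: the limit of > 5000 nM in this assay, at which 3 of the 3 values shown sit. The compounds shown leave open where any of them would actually read, and so whether chloro in place of naphthalen-2-yl changes anything.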